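A few compounds are considered here, and "the series" means these few. Any claim that something is new, unique, unknown or untested is made for them only; others in the source may bear on it.

Of the compounds shown here, three have been tested in a functional assay on A-375 cells (Homo sapiens) for cytotoxicity, read by MTT assay, with a stated time of 48 h; on this read-out higher numbers stand for weaker inhibition and lower numbers for stronger inhibition. Compound 1 `CC1(C)S[C@@H]2/C(=C\C(=O)c3cc(C(F)(F)F)cc(C(F)(F)F)c3)C(=O)N2[C@H]1C(=O)OC(c1ccccc1)c1ccccc1` gives 39200 nM in this assay. Compound 2 `CC1(C)S[C@@H]2/C(=C\C(=O)c3ccc(F)cc3)C(=O)N2[C@H]1C(=O)OC(c1ccccc1)c1ccccc1` gives 17800 nM, the second highest of the three numbers, a weaker showing than that of compound 3 `CC1(C)[C@H](C(=O)OC(c2ccccc2)c2ccccc2)N2C(=O)/C(=C/C(=O)c3ccccc3)[C@H]2[S+]1[O-]`, which gives 4500 nM, but a stronger one than that of compound 1. Against both neighbours the gap lies beyond the usual scatter, so compound 2 sits clearly between them.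

Compound 4 `CC1(C)S[C@@H]2/C(=C\C(=O)c3ccc(C(F)(F)F)cc3)C(=O)N2[C@H]1C(=O)OC(c1ccccc1)c1ccccc1` has not been measured. It differs from compound 2 in one place: trifluoromethyl in place of fluoro on an aromatic carbon. The change sits on the six-membered aromatic ring of carbon only, turning the (4-fluorophenyl)carbonyl group into a (4-(trifluoromethyl)phenyl)carbonyl group. Within the data shown here, no measured pair shows this exact change, so its size is uncertain. Compound 1, which carries two trifluoromethyl groups on that ring, gives the highest number, and so the step from compound 2 to compound 4 is expected to be small and, if anything, toward a higher number, a 1.4-fold higher number from compound 2 to compound 4 (0.15 log units; within the scatter). Compound 4 is therefore estimated at 25000 nM in this assay, within a range from 9000 nM to 65000 nM.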

Compound 4, half-maximal inhibitory concentration: 26700 nM
For compound 4 the middle estimate is 1.1-fold (0.03 log units) below the measured one; the range from low to high includes it.
By their numbers in this assay, from the lowest: compound 3; then compounds 2, 4 and 1 (each within the scatter of the next, the first and the last beyond it).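

In this assay, trifluoromethyl in place of fluoro on the aromatic carbon gives a 1.5-fold higher number from compound 2 to compound 4 (0.18 log units; within the scatter), so the two compounds cannot be told apart in this assay. Among these compounds, this is the first direct comparison at this position, and it shows that a group of four heavy atoms can stand where a single fluorine stood without a step beyond the usual scatter. No measurement at hand offers an explanation for this result.

Still open, going by these compounds, is whether a group of a different kind on the same carbon, such as an amine or a carboxylic acid, would give a step beyond the scatter. Also open, on these data alone, is whether this exchange would read the same way on cells other than those used here.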